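This account rests on a few compounds, and the source may have more. Where it says the series, first, only, none or still open, it means among the compounds named here.

Compound 1 `COc1ccc(/C=C2\CCC/C(=C\c3ccccc3Cl)C2=O)cc1OC`: 6800 nM
Compound 2 `COc1ccc(/C=C2\CCC/C(=C\c3cccc(Cl)c3Cl)C2=O)cc1OC`: 8800 nM

Both compounds were tested in a functional assay on HT-1080 cells (Homo sapiens) for cytotoxicity, read by MTT assay, with a stated time of 72 h; a lower number here means a stronger inhibitor, a higher number a weaker inhibitor. There compound 2 gives 8800 nM and cannot be told apart from compound 1 at 6800 nM, so the pair offers no ranking.

The next compound is compound 3 `COc1ccc(/C=C2\CCC/C(=C\c3ccc(O)c(Cl)c3)C2=O)cc1OC`, and it differs from compound 2 in one group: 3-chloro-4-hydroxyphenyl in place of 2,3-dichlorophenyl on a double-bonded chain carbon bound to a double-bonded ring carbon. In plain words, 3-chloro-4-hydroxyphenyl takes the place of 2,3-dichlorophenyl on a double-bonded chain carbon bound to a double-bonded ring carbon.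

Within the data shown here, the only measured step that bears on this is a 1.3-fold higher number from compound 1 to compound 2 (0.11 log units; within the scatter), which came from chloro in place of hydrogen on an aromatic carbon. Neither measured compound carries a hydrogen-bond donor, so this step is a thin guide to the new change. Starting from compound 2 at 8800 nM, no step beyond the scatter is expected in this assay. The estimated change is a 1.4-fold lower number from compound 2 to compound 3 (0.13 log units; within the scatter), and the uncertainty around it is wide. For compound 3 the expected value is 6500 nM, with an estimated range from 2000 nM to 15000 nM.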

Compound 3, half-maximal inhibitory concentration: 7600 nM
For compound 3 the middle estimate is 1.2-fold (0.07 log units) below the measured one, and the stated range covers the measured number.
By their numbers in this assay, from the lowest: compounds 1, 3 and 2 (each within the scatter of the next).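

Compound 3 is the only one of the three whose aromatic group, 3-chloro-4-hydroxyphenyl, carries a hydrogen-bond donor. In this assay putting this group in place of 2,3-dichlorophenyl gives a 1.2-fold lower number from compound 2 to compound 3 (0.06 log units; within the scatter) and putting it in place of 2-chlorophenyl gives a 1.1-fold higher number from compound 1 to compound 3 (0.05 log units; within the scatter) so on this double-bonded chain carbon, the three aromatic groups shown cannot be told apart, even though the new one brings a hydroxyl group that the other two lack. No independent measurement is available that could explain this result.

As far as these compounds go, all three compounds keep at least one chlorine on this aromatic group, so it remains open whether a group without chlorine, such as a phenyl ring bearing only an amine or a carboxylic acid, would give a number that differs beyond the scatter. The rest of the shared core is the same in all three compounds, so they also say nothing about what a change elsewhere in the structure would do.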